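Compound 3 to compound 4: propyl for 4-nitrophenyl

A few compounds are considered here, and "the series" means these few. Any claim that something is new, unique, unknown or untested is made for them only; others in the source may bear on it.

In a functional assay on A549 cells (Homo sapiens) for inhibition, read by MTT assay, with a stated time of 48 h (a lower number here means a stronger inhibitor, a higher number a weaker inhibitor), compound 1 (`Oc1cccc(C(c2c[nH]c3ccc(Br)cc23)c2c[nH]c3ccc(Br)cc23)c1`) gives 8000 nM, compound 2 (`COc1ccc(C(c2c[nH]c3ccc(Br)cc23)c2c[nH]c3ccc(Br)cc23)cc1`) gives 10000 nM and compound 3 (`O=[N+]([O-])c1ccc(C(c2c[nH]c3ccc(Br)cc23)c2c[nH]c3ccc(Br)cc23)cc1`) gives 5500 nM. Compound 3 thus sits level with the others within the scatter: a 1.5-fold lower number from compound 1 to compound 3 (0.16 log units; within the scatter) and a 1.8-fold lower number from compound 2 to compound 3 (0.26 log units; within the scatter), while a 1.3-fold higher number from compound 1 to compound 2 (0.10 log units; within the scatter).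

Compound 4 (`CCCC(c1c[nH]c2ccc(Br)cc12)c1c[nH]c2ccc(Br)cc12`) has propyl in place of 4-nitrophenyl on a saturated chain carbon bound to two aromatic carbons. Going by the values given here, the measured steps only exchange one substituted phenyl for another, and no measured compound has a chain there, so they are a weak guide.

No shift beyond the scatter is expected in this assay, and the estimated step is a 1.5-fold higher number from compound 3 to compound 4 (0.16 log units; within the scatter). For compound 4 the expected value is 8000 nM, with an estimated range of 2500 nM to 25000 nM.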

Compound 4, half-maximal inhibitory concentration: 6500 nM
Estimate against measurement, compound 4: 1.2-fold (0.09 log units) above, and the stated range covers the measured number.
By their numbers in this assay, from the lowest: compounds 3, 4, 1 and 2 (each within the scatter of the next).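

In this assay the substituted phenyl on the saturated chain carbon bound to two aromatic carbons gives way to ringless propyl with no shift beyond the scatter (a 1.2-fold higher number from compound 3 to compound 4 (0.07 log units; within the scatter)) (a 1.5-fold lower number from compound 2 to compound 4 (0.19 log units; within the scatter)) (a 1.2-fold lower number from compound 1 to compound 4 (0.09 log units; within the scatter)). Among these four compounds, then, an aromatic ring at this place is not required to stay level, even with 9 heavy atoms leaving and 3 entering in the step from 4-nitrophenyl. No evidence bears on why this place tolerates the change.

On these data alone, whether a longer chain, an amine or a carboxylic acid here would stay level with propyl remains open.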